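Replacing a Bicyclic Urea Substituent with a Short Chain

The source may report more compounds than this note shows. Statements on the series, on what has been measured and on what is new or still open speak of the compounds shown alone.

Going by the values given here, compound 2 `COc1ccc(Cl)cc1C(=O)NCCC1CCN(S(=O)(=O)NC(=O)NC[C@@H]2C[C@@H]3C=C[C@@H]2C3)CC1` is the lower of the two compounds measured so far: in a functional assay on the whole organism (blood) with Rattus norvegicus as the target, with stated times of 24 h and 1 h, at a dose of 1 mg/kg by the intraperitoneal route (a lower number here means a weaker effect, a higher number a stronger effect of the compound at the dose given), compound 2 gives 27%, while compound 1 `COc1ccc(Cl)cc1C(=O)NCCC1CCN(S(=O)(=O)NC(=O)NC2CCCCC2)CC1` gives 39%. Among the compounds with values here, the only measured step, a number 12 percentage points lower from compound 1 to compound 2 (beyond the scatter), shows that exchanging the group on the amide-type nitrogen shifted the read-out modestly. Compound 3 `CCCNC(=O)NS(=O)(=O)N1CCC(CCNC(=O)c2cc(Cl)ccc2OC)CC1` differs from compound 2 by a group of 2 heavy atoms (2 carbon; no ring) in place of a group of 7 heavy atoms (7 carbon; 2 five-membered non-aromatic rings of carbon only), on a saturated chain carbon bound to an amide-type nitrogen. Within the data shown here, no measured step covers this particular change, so only a modest shift in either direction is expected, a number 6 percentage points higher from compound 2 to compound 3 (within the scatter). Compound 3 is therefore estimated at 33%, within a range of 18% to 48%.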

Compound 3, a percentage reported as activity, at one dose (the size of the read-out at that dose, not a potency): 24%
Beside the measured number, compound 3's estimate is 9 percentage points above it; measured number inside the range.
By their numbers in this assay, from the lowest: compounds 3 and 2 (each within the scatter of the next); then compound 1.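

In this assay, ethyl in place of the ring-bearing group, on a saturated chain carbon bound to an amide-type nitrogen, gives a number 3 percentage points lower from compound 2 to compound 3 (within the scatter), so at this dose the rings, the double bond and the defined stereocentres make no visible difference. Propyl in place of cyclohexyl on an amide-type nitrogen gives a number 15 percentage points lower from compound 1 to compound 3 (beyond the scatter), which sets compound 1 apart from the open-chain compound 3. No evidence explains these numbers. From the compounds shown here alone, how a longer chain such as butyl, or a phenyl ring, would read at this position remains open.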